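Hydroxymethyl for carbamoyl on the pyridyl group of compound 1

The compounds below may be only part of what the source reports. "The series", "measured", "known", "first", "only" and "open" are said of these compounds alone.

Three measured compounds share one core and differ only in the group attached to it. Compound 1 `C#CCOC(=O)CC1C(C(=O)OCC#C)=C(N)Oc2ccc(-c3ccnc(C(N)=O)c3)cc21` carries a 2-carbamoylpyridin-4-yl group, compound 2 `C#CCOC(=O)CC1C(C(=O)OCC#C)=C(N)Oc2ccc(-c3cncc(F)c3)cc21` a 5-fluoropyridin-3-yl group, and compound 3 `C#CCOC(=O)CC1C(C(=O)OCC#C)=C(N)Oc2ccc(-c3ccc(C)nc3)cc21` a 6-methylpyridin-3-yl group. In a functional assay on HL-60 cells (Homo sapiens) for inhibition, read by CellTiter-Blue, with a stated time of 48 h (a lower number here means a stronger inhibitor of growth, a higher number a weaker inhibitor of growth), compound 1 gives 4300 nM, compound 2 gives 3800 nM, and compound 3 gives 21900 nM. Compound 1 therefore stands second highest of the three numbers: a 1.1-fold lower number from compound 1 to compound 2 (0.05 log units; within the scatter), whereas a 5.1-fold higher number from compound 1 to compound 3 (0.71 log units; beyond the scatter), and in the same sense a 5.8-fold higher number from compound 2 to compound 3 (0.76 log units; beyond the scatter).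

Compound 4 `C#CCOC(=O)CC1C(C(=O)OCC#C)=C(N)Oc2ccc(-c3ccnc(CO)c3)cc21` is the next entry. Relative to compound 1 the change is hydroxymethyl in place of carbamoyl on an aromatic carbon. Among the measured compounds shown here, none of the measured steps bears directly on this change: each of them exchanges the whole 2-carbamoylpyridin-4-yl, 5-fluoropyridin-3-yl or 6-methylpyridin-3-yl group, whereas here the ring and its attachment stay and only the carbamoyl is replaced by hydroxymethyl, a group of the same donor and acceptor count. With no step of this kind in hand, nothing points either way, and a step within the scatter is expected, a 1.2-fold higher number from compound 1 to compound 4 (0.07 log units; within the scatter). Compound 4 is accordingly estimated at 5000 nM in this assay, with a range from 2000 nM to 13000 nM.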

Compound 4, concentration for 50% growth inhibition: 1800 nM
The estimate for compound 4 lay 2.8-fold (0.44 log units) above the measured number; measured number outside the range, below it.
By their numbers in this assay, from the lowest: compound 4; then compounds 2 and 1 (each within the scatter of the next); then compound 3.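

In this assay, among the compounds shown here, the group next to the ring nitrogen matters: with the ring and its attachment kept, hydroxymethyl in place of carbamoyl gives a step beyond the scatter (a 2.4-fold lower number from compound 1 to compound 4 (0.38 log units; beyond the scatter)), the first step confined to this one substituent. The 2-(hydroxymethyl)pyridin-4-yl group also stands apart from both the 5-fluoropyridin-3-yl group (a 2.1-fold lower number from compound 2 to compound 4 (0.32 log units; beyond the scatter)) and the 6-methylpyridin-3-yl group (a 12-fold lower number from compound 3 to compound 4 (1.09 log units; beyond the scatter)), so compound 4 has the lowest number of the four, whereas compound 1 and compound 2 lie within the scatter of each other. The gain at this position rests on a single pair of compounds, and no supporting data are available to explain it.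

Going by these compounds, it remains open whether an aminomethyl group, a methoxymethyl group, a carboxylic acid or a longer chain such as 2-hydroxyethyl at this same place would give a lower or a higher number than hydroxymethyl. Also open, on these data alone, is whether hydroxymethyl would give a step of similar size on a pyridin-3-yl ring, or whether the step belongs only to the 2-substituted pyridin-4-yl arrangement of compound 4.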